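A few compounds are considered here, and "the series" means these few. Any claim that something is new, unique, unknown or untested is made for them only; others in the source may bear on it.

Compound 1 `Fc1cccc(F)c1C#Cc1nccc2ccccc12` stands lowest of the two compounds measured in a functional assay on LS174T cells (Homo sapiens) for inhibition, with a stated time of 4 days, tested at 1 uM; on this read-out lower numbers stand for a weaker effect and higher numbers for a stronger effect at the one concentration tested. In this assay compound 1 gives 35.4%, while compound 2 `Fc1cccc(F)c1C#Cc1ccc2cn[nH]c2c1` gives 81.5%, a gap beyond the scatter. Compound 3 `Fc1ccc2ccnc(C#Cc3c(F)cccc3F)c2c1` differs from compound 1 by a single change: fluoro in place of hydrogen on an aromatic carbon. For the measured compounds named here, no measured pair shows this change, so the step from compound 1 to compound 3 in this assay is expected to be small, within the scatter or at most modestly upward. Compound 3 is therefore estimated at 40% in this assay, with a range from 20% to 62%. The expected step is then a number 4.6 percentage points higher from compound 1 to compound 3 (within the scatter).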

Compound 3, a percentage reported as inhibition, at one concentration (the size of the read-out at that concentration, not a potency): 71.1%
Compound 3: the middle estimate sits 31.1 percentage points below what was measured, outside the stated range (above it).
By their numbers in this assay, from the lowest: compound 1; then compound 3; then compound 2.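

In this assay fluoro in place of hydrogen on an aromatic carbon of the core gives a number 35.7 percentage points higher from compound 1 to compound 3 (beyond the scatter) so one added fluorine atom is enough for a large change in the read-out. For the compounds shown here, no earlier pair differed in one place, and this is the first sign that this position, meta to a fused ring and para to a fused ring, responds to substitution. Nothing at hand explains the size of this step. From the compounds shown here alone, whether it is particular to fluoro, or would also follow from chloro, methoxy or an amine at this place, stays open. Also open, going by these compounds, is whether fluoro elsewhere on this ring would give a similar step.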